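This account rests on a few compounds, and the source may have more. Where it says the series, first, only, none or still open, it means among the compounds named here.

Measured compounds:
- compound 1, `CC1(C)O[C@@H]2CC[C@](C)(O)[C@H](CCC3C(C=O)=CCC4C(CC[C@@]4(C)O)C3(C)C)[C@@]2(C)CCC1=O`: 5.6 nM
- compound 2, `CC1(C)O[C@@H]2CC[C@](C)(O)[C@H](CC[C@@]34O[C@]3(C)[C@H](O)CC3C(CC[C@@]3(C)O)C4(C)C)[C@@]2(C)CC[C@H]1O`: 8.6 nM

Both compounds were tested in a functional assay on KB 3-1 cells (Homo sapiens) for cytotoxicity, read by MTT assay, with a stated time of 68 h, tested at 5 uM; on this read-out lower numbers stand for stronger inhibition and higher numbers for weaker inhibition. Compound 1 has the lower of the two numbers, and compound 2 sits a short distance from it, a gap that falls within the usual scatter of this assay; on these two values alone neither can be called the more potent.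

The step considered here leads from compound 1 to compound 3, `CC1=CCC2C(CC[C@@]2(C)O)C(C)(C)C1CC[C@@H]1[C@@]2(C)CCC(=O)C(C)(C)O[C@@H]2CC[C@]1(C)O`. Going by the values given here, the only change is methyl in place of formyl on a double-bonded ring carbon. Among the compounds with values here, no measured pair with this change is available, so its effect has to be judged from the two numbers above and the nature of the swap: a formyl with its hydrogen-bond acceptor and double bond is removed, and a plain methyl takes its place.

My expectation is that compound 3 loses potency, with a step of an 11-fold higher number from compound 1 to compound 3 (1.03 log units; beyond the scatter) that lies beyond the scatter. For compound 3 in this assay I estimate 60 nM, with a range from 10 nM to 400 nM.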

Compound 3, half-maximal inhibitory concentration: 5.2 nM
Beside the measured number, compound 3's estimate is 12-fold (1.06 log units) above it; the whole stated range lies above it.
By their numbers in this assay, from the lowest: compounds 3, 1 and 2 (each within the scatter of the next).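

In this assay, putting methyl in place of formyl on a double-bonded ring carbon gives a 1.1-fold lower number from compound 1 to compound 3 (0.03 log units; within the scatter) and so leaves the two compounds indistinguishable on this read-out. The earlier compounds shown here offered no pair that differed only at this spot, so the role of the formyl could not be read from them. This pair shows that, in these two compounds, the formyl with its carbonyl double bond and its hydrogen-bond acceptor is not required for a number in this range, since a plain methyl on the same ring carbon serves equally well. No measurement at hand gives a reason for this result.

Going by these compounds, what a larger or quite different group would do on this ring carbon stays open, for example a carboxylic acid, an amine, a hydroxymethyl group or a longer chain. On these data alone, with a single pair to go on, it also remains unknown whether the same swap would read the same way if other parts of the shared core were different.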